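This account rests on a few compounds, and the source may have more. Where it says the series, first, only, none or still open, it means among the compounds named here.

Three members of one family have been tested in a functional assay on A549 cells (Homo sapiens) for cytotoxicity, read by MTT assay, with a stated time of 24 h, tested at 10 uM; on this read-out lower numbers stand for a stronger effect and higher numbers for a weaker effect at the one concentration tested. Compound 1 `CCCCCOC(=O)CCC(=O)N1CCN(CCCOc2cc3c(Nc4ccc(F)c(Cl)c4)ncnc3cc2OC)CC1` gives 87.1% in this assay. Compound 2 `CCCCCCOC(=O)CCC(=O)N1CCN(CCCOc2cc3c(Nc4ccc(F)c(Cl)c4)ncnc3cc2OC)CC1` gives 89.3%, and compound 3 `CCCCCCCCOC(=O)CCC(=O)N1CCN(CCCOc2cc3c(Nc4ccc(F)c(Cl)c4)ncnc3cc2OC)CC1` gives 87.3%. On these numbers compound 3 stands second highest of the three, closest to compound 1, and all three lie so near one another that none can be called stronger or weaker than another.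

The step of a number 2.2 percentage points higher from compound 1 to compound 2 (within the scatter) came with methyl in place of hydrogen on a saturated chain carbon, five bonds along the chain from an oxygen next to a carbonyl group. The step of a number 0.2 percentage points higher from compound 1 to compound 3 (within the scatter) came with propyl in place of hydrogen on a saturated chain carbon, five bonds along the chain from an oxygen next to a carbonyl group. The step of a number 2 percentage points lower from compound 2 to compound 3 (within the scatter) came with ethyl in place of hydrogen on a saturated chain carbon, six bonds along the chain from an oxygen next to a carbonyl group.

Compound 4 `CCCCCCCCCCCOC(=O)CCC(=O)N1CCN(CCCOc2cc3c(Nc4ccc(F)c(Cl)c4)ncnc3cc2OC)CC1` is not yet measured. It differs from compound 3 in this way: propyl in place of hydrogen on a saturated chain carbon, eight bonds along the chain from an oxygen next to a carbonyl group. All three measured steps lengthened the same chain and none moved the read-out beyond the scatter, so no step beyond the scatter is expected here either. Compound 4 is therefore expected to give about 88% in this assay, within the range 77% to 97%. That amounts to an expected step of a number 0.7 percentage points higher from compound 3 to compound 4 (within the scatter).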

Compound 4, a percentage reported as activity, at one concentration (the size of the read-out at that concentration, not a potency): 93.4%
The estimate for compound 4 lay 5.4 percentage points below the measured number; the measured number falls inside the stated range.
By their numbers in this assay, from the lowest: compounds 1, 3, 2 and 4 (each within the scatter of the next).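

In this assay, propyl in place of hydrogen on a saturated chain carbon, eight bonds along the chain from an oxygen next to a carbonyl group, gives the longest chain of the family so far, and the step is small enough to stay inside the usual noise (a number 6.1 percentage points higher from compound 3 to compound 4 (within the scatter)). Read from the shorter chains, the same compound 4 arises by pentyl in place of hydrogen, six bonds along the chain from that oxygen (a number 4.1 percentage points higher from compound 2 to compound 4 (within the scatter)), or by hexyl in place of hydrogen, five bonds along the chain from that oxygen (a number 6.3 percentage points higher from compound 1 to compound 4 (within the scatter)). The earlier compounds shown here showed this only for additions up to propyl, whereas even hexyl now leaves the read-out unresolved, so no compound of the four can be called stronger or weaker at the one concentration tested.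

No measurement at hand offers an explanation for these numbers. On these data alone, whether an amine or a carboxylic acid on this chain, or a still longer chain, would move the read-out beyond the scatter remains open.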